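Solubility notes on a methoxy-methyl ether to butyl change

This account rests on a few compounds, and the source may have more. Where it says the series, first, only, none or still open, it means among the compounds named here.

Measured so far:
compound 1 `COC(C)(C)CCOc1cccc(OCc2[nH]c3ccccc3c(=O)c2C)c1` — 2000 nM
compound 2 `Cc1c(COc2cncc(OCCC(C)(C)O)c2)[nH]c2ccccc2c1=O` — >= 100000 nM

For the measured compounds named here, in a physicochemical assay for solubility, at pH 6.8 (a lower number here means a less soluble compound, a higher number a more soluble compound), compound 1 gives 2000 nM, the only plain number in the set. For compound 2 this assay reports only a limit, >= 100000 nM; that reading is the limit of >= 100000 nM in this assay, at which 1 of the 2 values shown sits, and not a measured number. Going by the values given here, compound 1 therefore stands alone as the single numerical point, and no step between two measured compounds can be drawn from these data.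

Compound 3 `CCCCOc1cccc(OCc2[nH]c3ccccc3c(=O)c2C)c1` is the next compound to be measured in this assay. It differs from compound 1 by ethyl in place of 1-methoxy-1-methylethyl on a saturated chain carbon, two bonds along the chain from an oxygen on an aromatic ring. Without a measured step to lean on, the expected movement from compound 1 to compound 3 is modest, leaning toward lower solubility, and could well remain within the usual scatter of this assay. Compound 3 is estimated at 1200 nM, with a range of 300 nM to 5000 nM, which corresponds to an expected step of a 1.7-fold lower number from compound 1 to compound 3 (0.22 log units; within the scatter).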

Compound 3, solubility: < 1000 nM
Compound 3: a limit, no number; the forecaster's own chance of this, stated with the estimate: 5%; middle value at least 1.2-fold (0.07 log units) away from the limit.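

In this assay compound 3 carries no number, only a limit: the limit of < 1000 nM in this assay, at which 1 of the 3 values shown sits. Going from 3-methoxy-3-methylbutoxy to butoxy gives an at least 2.0-fold lower number from compound 1 to compound 3 (0.30 log units; that floor lies within the scatter), and this is the only single-place step shown at this position. Only a floor is known for this step, so the change is not shown to lie beyond the scatter, and its true size is not fixed.

As far as these compounds go, the actual reading for compound 3 remains open, and so does whether the change at this chain position moves this assay by more than the scatter; compound 2 differs from compound 1 and compound 3 in more than one place, so it does not settle either question. Also open, from the compounds shown here alone, is how a chain ending in an amine or a carboxylic acid, or a longer chain, would read in this assay on the core of compound 1.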